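This account rests on a few compounds, and the source may have more. Where it says the series, first, only, none or still open, it means among the compounds named here.

For the measured compounds named here, compound 3 `CN(C)C(=O)c1cc2cnc(Nc3ccc(NC(=O)CCCCN=C=S)cc3)nc2n1C1CCCC1` gives 82.5% in a functional assay on NCI-H1299 cells (Homo sapiens) for inhibition, read by CCK-8 assay, with a stated time of 72 h, tested at 10 uM (a higher number here means a stronger effect of the compound at the concentration tested, a lower number a weaker effect), the highest of the three numbers so far, though compound 2 `CN(C)C(=O)c1cc2cnc(Nc3ccc(C(=O)NCCCCN=C=S)cc3)nc2n1C1CCCC1` with 74.2% and compound 1 `CN(C)C(=O)c1cc2cnc(Nc3ccc(S(=O)(=O)NCCCN=C=S)cc3)nc2n1C1CCCC1` with 72.8% both lie within the scatter of it. The measured steps of a number 1.4 percentage points higher from compound 1 to compound 2 (within the scatter), a number 9.7 percentage points higher from compound 1 to compound 3 (within the scatter) and a number 8.3 percentage points higher from compound 2 to compound 3 (within the scatter) each swap a whole group on an aromatic carbon and none reach beyond the scatter. Compound 4 `CN(C)C(=O)c1cc2cnc(Nc3ccc(NC(=O)CCCCCN=C=S)cc3)nc2n1C1CCCC1` differs from compound 3 by a lesser change: a group of 4 heavy atoms (2 carbon, 1 nitrogen, 1 sulfur; no ring) in place of a group of 3 heavy atoms (1 carbon, 1 nitrogen, 1 sulfur; no ring), on a saturated chain carbon, four bonds along the chain from a carbonyl carbon. Going by the values given here, no measured step lengthens the saturated chain in this way, so the three steps bear only loosely, suggesting that exchanges in this part of the molecule leave this assay near the same level. The step of a number 2.5 percentage points lower from compound 3 to compound 4 (within the scatter) is therefore expected to be none beyond the scatter. Compound 4 is estimated at 80%, in the range 65% to 92%.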

Compound 4, a percentage reported as inhibition, at one concentration (the size of the read-out at that concentration, not a potency): 85%
For compound 4 the middle estimate is 5 percentage points below the measured one, within the range that was stated.
By their numbers in this assay, from the lowest: compounds 1, 2, 3 and 4 (each within the scatter of the next, the first and the last beyond it).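

In this assay the added carbon on the saturated chain, four bonds along the chain from a carbonyl carbon, gives a number 2.5 percentage points higher from compound 3 to compound 4 (within the scatter) and so shows no separable effect of this lengthening. Only the whole-group exchanges on an aromatic carbon, a number 10.8 percentage points higher from compound 2 to compound 4 (beyond the scatter) and a number 12.2 percentage points higher from compound 1 to compound 4 (beyond the scatter), clear the scatter, and each alters more than chain length, so neither isolates one feature of the group. No evidence on the cause of these differences is available here.

As far as these compounds go, whether a longer chain holds this level in this assay remains open. Also open, from the compounds shown here alone, is how an amine would read in place of the group of 4 heavy atoms.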